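Inverting one ring stereocentre in a macrocyclic cytotoxin

The source may hold more compounds than are shown below. What is called first, only, known or untested is meant among the compounds shown, and "the series" means these compounds.

Measured so far:
Compound 1, `CC1=C\C[C@H](O)/C=C/C(C)=C/[C@@H](NC(=O)[C@H](C)O)[C@@H](C)C(=O)/C(C)=C/C[C@H](O)\C=C\1`: 45400 nM
Compound 2, `CC(=O)C(=O)N[C@@H]1/C=C(C)/C=C/[C@@H](O)C/C=C(C)/C=C/[C@@H](O)C/C=C(\C)C(=O)[C@H]1C`: 72900 nM

Both compounds were tested in a functional assay on HeLa cells (Homo sapiens) for cytotoxicity, read by MTT assay, with a stated time of 72 h; a higher number here means a weaker inhibitor, a lower number a stronger inhibitor. Compound 1 gives 45400 nM and compound 2 gives 72900 nM; the two numbers lie within the usual scatter of each other, so neither compound can be called stronger or weaker than the other on this evidence. Both are weak inhibitors of cell growth, with numbers far up in the micromolar range.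

Compound 3, `CC(=O)C(=O)N[C@@H]1/C=C(C)/C=C/[C@@H](O)C/C=C(C)/C=C/[C@@H](O)C/C=C(\C)C(=O)[C@@H]1C`, has not yet been measured. It differs from compound 2 only in configuration: the two compounds have the same atoms and bonds and differ only in configuration as drawn: 1 of 9 stereo elements differ; a stereocentre at a saturated ring carbon is drawn S in compound 2 and R in compound 3. Nothing else in the molecule moves. Within the data shown here, no step between two measured compounds is known here, so there is no measured precedent for what a single inversion at this ring carbon does in this assay. The reasonable expectation is a step that stays within the scatter, in no firm direction, while allowing for the chance that the inverted centre matters more than that.

The estimated number for compound 3 in this assay is therefore 75000 nM, within a range from 20000 nM to 250000 nM, which means an expected step of a 1.0-fold higher number from compound 2 to compound 3 (0.01 log units; within the scatter).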

Compound 3, half-maximal inhibitory concentration: > 100000 nM
Compound 3: no number, only a limit; the forecaster's own chance of this, stated with the estimate: 15%; at least 1.3-fold (0.12 log units) between middle value and limit.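

In this assay compound 3 gives > 100000 nM, which is a limit of the assay and not a number. The single inversion at this saturated ring carbon gives an at least 1.3-fold higher number from compound 2 to compound 3 (0.13 log units; that floor lies within the scatter), and this floor cannot tell how far the number really moves, because the step rests on a limit: the limit of > 100000 nM in this assay, at which 1 of the 3 values shown sits.
Among these compounds, the change of acetyl in place of 1-hydroxyethyl on a carbonyl carbon gives an at least 2.2-fold higher number from compound 1 to compound 3 (0.34 log units; beyond the scatter), the first step in this set that lies beyond the scatter, so this inverted compound with its acetyl group can be placed as weaker than the 1-hydroxyethyl compound even without a true number.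

As far as these compounds go, the true size of the inversion stays open, and with it the question of whether this ring carbon matters much or little for cytotoxicity in these cells. Also open, from the compounds shown here alone, is what other groups would do in place of the acetyl on that carbonyl carbon, such as an aminomethyl group or a carboxylic acid, and whether 1-hydroxyethyl would behave the same way with either configuration at the ring carbon.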